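The compounds below may be only part of what the source reports. "The series", "measured", "known", "first", "only" and "open" are said of these compounds alone.

Compound 1 `CC(C)(C)OC(=O)NCCCCCNC(=O)CN1CN(c2ccccc2)C2(CCN(C(=O)c3ccc(C(C)(C)C)cc3)CC2)C1=O`: 13700 nM
Compound 2 `CS(=O)(=O)NCCCNC(=O)CN1CN(c2ccccc2)C2(CCN(C(=O)c3ccc(C4CCCCC4)cc3)CC2)C1=O`: 3800 nM
Compound 3 `CC(C)(C)c1ccc(C(=O)N2CCC3(CC2)C(=O)N(CC(=O)NCCCN)CN3c2ccccc2)cc1`: 4200 nM

All three were measured in an assay on HEK293 cells for displacement of a labelled ligand from NPC1-like intracellular cholesterol transporter 1 (Homo sapiens); a higher number here means a weaker inhibitor, a lower number a stronger inhibitor. Among them, compound 3 holds the second highest number: compound 2 sits close by, the gap lying within the scatter, while compound 1 lies further off, with a gap beyond the scatter. Compound 4 `CC(C)(C)c1ccc(C(=O)N2CCC3(CC2)C(=O)N(CC(=O)N2CCCCC2CO)CN3c2ccccc2)cc1` has not yet been measured. It differs from compound 3 in one place: 2-(hydroxymethyl)piperidin-1-yl in place of (3-aminopropyl)amino on a carbonyl carbon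

Going by the values given here, only one measured step touches the same part of the molecule, the one in which compound 1 becomes compound 3: a 3.3-fold lower number from compound 1 to compound 3 (0.51 log units; beyond the scatter). Compound 1, carrying the 2-((tert-butoxycarbonyl)amino)ethyl group in place of the free amino group, gives 13700 nM, so the free amino group seems to help modestly. Compound 2 differs from compound 3 in more than one place, so its number can only be noted as standing within the scatter of that of compound 3.

Since compound 4 also gives up the free amino group, a modest weakening is expected, because the step of a 3.3-fold lower number from compound 1 to compound 3 (0.51 log units; beyond the scatter) ran the other way when that group was introduced; the step expected here is a 2.1-fold higher number from compound 3 to compound 4 (0.33 log units; beyond the scatter). Compound 4 is therefore estimated at about 9000 nM, within a range from 3000 nM to 30000 nM.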

Compound 4, half-maximal inhibitory concentration: 11800 nM
Compound 4: the middle estimate sits 1.3-fold (0.12 log units) below what was measured, and the stated range covers the measured number.
By their numbers in this assay, from the lowest: compounds 2 and 3 (each within the scatter of the next); then compounds 4 and 1 (each within the scatter of the next).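

In this assay, replacing the open (3-aminopropyl)amino chain on the carbonyl carbon with 2-(hydroxymethyl)piperidin-1-yl gives a 2.8-fold higher number from compound 3 to compound 4 (0.45 log units; beyond the scatter), a modest step. The earlier step changed only the end of the chain, whereas this one swaps the whole group for one with a six-membered non-aromatic ring and one hydrogen-bond donor instead of two, so a second, very different group without the free amino group also gives a higher number than compound 3; compound 2 also lacks that amino group, but it differs from compound 3 in more than one place and cannot be counted for or against this trend. No measurement among those shown accounts for the change.

This single step combines several changes, so the loss of the terminal amine, the closing of the ring and the arrival of the hydroxyl cannot be told apart. A plain piperidin-1-yl group, a (3-hydroxypropyl)amino chain or a piperidine ring bearing an aminomethyl group in place of hydroxymethyl would each help separate these contributions.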